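The source may hold more compounds than are shown below. What is called first, only, known or untested is meant among the compounds shown, and "the series" means these compounds.

Growth inhibition in a functional assay on A549 cells (Homo sapiens) for inhibition; a lower number here means a stronger inhibitor of growth, a higher number a weaker inhibitor of growth:
- compound 1 `Cc1ccc(N2CCN(CC(=O)Nc3ccc(-c4nc5ccccc5s4)cc3)CC2)cc1`: 200 nM
- compound 2 `O=C(CN1CCN(c2ccccc2F)CC1)Nc1ccc(-c2nc3ccccc3s2)cc1`: 200 nM
- compound 3 `O=C(CN1CCN(c2ccccc2)CC1)Nc1ccc(-c2nc3ccccc3s2)cc1`: not yet measured

Compound 2 stands level with compound 1, and compound 2 gives 200 nM. The next change is hydrogen in place of fluoro on an aromatic carbon, turning 2-fluorophenyl to phenyl. Among the measured compounds shown here, the one measured step bearing on it, a change on the same aromatic ring, shows no change at the digits printed from compound 1 to compound 2 (within the scatter). No step beyond the scatter is therefore expected in this assay, in either direction. The expected outcome is no change at the digits printed from compound 2 to compound 3 (within the scatter). For compound 3 the estimate is 200 nM, with an expected range of 90 nM to 450 nM.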

Compound 3, concentration for 50% growth inhibition: 200 nM
Estimate against measurement, compound 3: no gap at the digits printed; the measured number falls inside the stated range.
By their numbers in this assay, from the lowest: compounds 1, 2 and 3 (each within the scatter of the next).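

In this assay, hydrogen in place of fluoro gives no change at the digits printed from compound 2 to compound 3 (within the scatter), and hydrogen in place of methyl gives no change at the digits printed from compound 1 to compound 3 (within the scatter). The unsubstituted phenyl therefore sits level with both substituted rings, so neither fluoro nor methyl is required on this ring for the growth inhibition seen here. No evidence on the cause accompanies these results. Still open, from the compounds shown here alone, is whether a carboxylic acid, an amine or a longer alkyl chain on this phenyl would shift the value. The compounds shown also leave open any change to the acetamide link or the shared core.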